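Naphthalen-2-yl to 4-(methylsulfanyl)phenyl on the shared core

The source may hold more compounds than are shown below. What is called first, only, known or untested is meant among the compounds shown, and "the series" means these compounds.

Measured in a functional assay on WM 266-4 cells (Homo sapiens) for antiproliferative activity, read by MTT assay, with a stated time of 24 h; on this read-out lower numbers stand for stronger inhibition of growth and higher numbers for weaker inhibition of growth:
- compound 1 `FC(F)(F)c1ccc(C2CC(c3ccc4c(c3)OCCO4)=NN2c2ccccc2)cc1`: > 100000 nM (a limit)
- compound 2 `c1ccc(N2N=C(c3ccc4c(c3)OCCO4)CC2c2ccc3ccccc3c2)cc1`: 13900 nM

Going by the values given here, compound 2 holds the only actual number so far. The value of compound 1 is a limit. Compound 3 `CSc1ccc(C2CC(c3ccc4c(c3)OCCO4)=NN2c2ccccc2)cc1` carries 4-(methylsulfanyl)phenyl in place of naphthalen-2-yl on a saturated ring carbon. Among the compounds with values here, one measured step bears on this place: an at least 7.1-fold lower number from compound 1 to compound 2 (0.85 log units; beyond the scatter). Compound 3 returns to a substituted phenyl, as in compound 1, so part of that step is expected to reverse in this assay, towards a moderately higher number. The expected step is a 1.8-fold higher number from compound 2 to compound 3 (0.25 log units; within the scatter). The estimate for compound 3 is 25000 nM, with an expected range of 5000 nM to 100000 nM.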

Compound 3, concentration for 50% growth inhibition: 6870 nM
Estimate against measurement, compound 3: 3.6-fold (0.56 log units) above; the range from low to high includes it.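

In this assay, a single substituted phenyl on the saturated ring carbon does not fall short of the larger naphthalen-2-yl, with a 2.0-fold lower number from compound 2 to compound 3 (0.31 log units; beyond the scatter). With the phenyl kept, methylsulfanyl in place of trifluoromethyl on an aromatic carbon gives an at least 14-fold lower number from compound 1 to compound 3 (1.16 log units; beyond the scatter), so the substituent on that phenyl alone can carry a large change. The size of that step rests on a limit for compound 1: the limit of > 100000 nM in this assay, at which 1 of the 3 values shown sits.

From the compounds shown here alone, it remains open whether an unsubstituted phenyl, a methoxy group or a dimethylamino group at that place would match methylsulfanyl. Going by these compounds, the effect of a longer thioether chain also remains open.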